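The compounds below may be only part of what the source reports. "The series", "measured", "known", "first", "only" and "open" are said of these compounds alone.

Compound 1 `Nc1nc(NCc2ccccc2)c2ncn(/C=C3/CC3(CO)CO)c2n1` gives in an ADME assay on HFF cells (Homo sapiens) for cytotoxicity, with a stated time of 8 days (a lower number here means that less compound is tolerated, a higher number that more compound is tolerated), only a limit of the assay, > 300000 nM.
Compound 2 `CSc1nc(N)nc2c1ncn2/C=C1/CC1(CO)CO` gives in this assay a limit as well, > 300000 nM.
Compound 3 `Nc1nc(OCc2ccccc2)c2ncn(/C=C3/CC3(CO)CO)c2n1` gives in this assay likewise a limit, > 300000 nM.

Compound 3 therefore stands nowhere in particular on the numbers shown: its value is a limit, and the two further values are limits too, all three sitting at the same point (the limit of > 300000 nM in this assay, at which 3 of the 3 values shown sit). The steps between the measured compounds are accordingly unreadable: from compound 1 to compound 2 a step that the two limits leave unreadable from compound 1 to compound 2, from compound 1 to compound 3 a step that the two limits leave unreadable from compound 1 to compound 3, and from compound 2 to compound 3 a step that the two limits leave unreadable from compound 2 to compound 3.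

Compound 4 `Nc1nc(SCc2ccccc2)c2ncn(/C=C3/CC3(CO)CO)c2n1` differs from compound 3 in one place: benzylsulfanyl in place of benzyloxy on an aromatic carbon. The step from compound 2 to compound 3 also exchanges a sulfur-bearing group for an oxygen-bearing one, and the step from compound 1 to compound 3 also touches the same position, but both are hidden by the limits, so their size says nothing about what to expect. In this assay no step beyond the scatter can be read from the data, and none is expected here either; the expected step from compound 3 to compound 4 is a number no higher from compound 3 to compound 4 (the limit leaves the size open). Compound 4 is estimated at 300000 nM, with a range from 100000 nM to 1000000 nM, and it is expected most likely to come back as another limit.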

Compound 4, half-maximal cytotoxic concentration: > 300000 nM
Compound 4 was reported as a limit (the forecaster's own chance of this, stated with the estimate: 85%); the middle value sits exactly at the limit.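

In this assay compound 4 gives a limit as well, > 300000 nM. No step linking compound 4 to compound 1, compound 2 or compound 3 can be read, as all the values are limits: the limit of > 300000 nM in this assay, at which 4 of the 4 values shown sit.

The compounds shown leave open whether benzylsulfanyl, benzyloxy, benzylamino and methylsulfanyl differ at all in how much compound is tolerated.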